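Trimethoxyphenyl amide: expected cytotoxicity from two neighbours

The source may hold more compounds than are shown below. What is called first, only, known or untested is meant among the compounds shown, and "the series" means these compounds.

Compound 1 `Cc1ccc(C(=O)Nc2cccc(Cl)c2)cc1C#Cc1cc(-c2cnn(C)c2)cnc1N` was tested in an ADME assay on RBL-2H3 cells (Rattus norvegicus) for cytotoxicity, read by CCK-8 assay, with a stated time of 24 h (on this read-out higher numbers stand for lower toxicity in this test and lower numbers for higher toxicity in this test), where compound 1 gives 24.8 nM. Its companion compound 2 `Cc1ccc(C(=O)Nc2ccc(OC(F)(F)F)cc2)cc1C#Cc1cc(-c2cnn(C)c2)cnc1N` differs only in the group on the amide-type nitrogen; in this assay compound 2 gives 41 nM. Of the two numbers, compound 1 stands lowest, with compound 2 as its nearest neighbour, and the single step shown is a 1.7-fold higher number from compound 1 to compound 2 (0.22 log units; within the scatter).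

Compound 3 `COc1cc(NC(=O)c2ccc(C)c(C#Cc3cc(-c4cnn(C)c4)cnc3N)c2)cc(OC)c1OC` has not yet been measured in this assay. It differs from compound 1 by 3,4,5-trimethoxyphenyl in place of 3-chlorophenyl on an amide-type nitrogen. For the measured compounds named here, the one measured step that bears on this change is a swap of the same kind at the amide-type nitrogen, a 1.7-fold higher number from compound 1 to compound 2 (0.22 log units; within the scatter), and it stayed within the scatter. Going by the values given here, no measured compound carries a trimethoxyphenyl group, so the data give no ground for a step beyond the scatter in either direction. Compound 3 is therefore expected to show a 1.4-fold higher number from compound 1 to compound 3 (0.15 log units; within the scatter), a step of no more than the usual size. The estimate for compound 3 in this assay is 35 nM, with a range from 12 nM to 100 nM.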

Compound 3, half-maximal cytotoxic concentration: 2.9 nM
Compound 3: the middle estimate sits 12-fold (1.08 log units) above what was measured, and the stated range ends above it.
By their numbers in this assay, from the lowest: compound 3; then compounds 1 and 2 (each within the scatter of the next).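

At the amide-type nitrogen, the choice of aryl group proves able to move the read-out well beyond the scatter in this assay: 3,4,5-trimethoxyphenyl in place of 3-chlorophenyl gives (an 8.6-fold lower number from compound 1 to compound 3 (0.93 log units; beyond the scatter)), and in place of 4-(trifluoromethoxy)phenyl it gives (a 14-fold lower number from compound 2 to compound 3 (1.15 log units; beyond the scatter)), in both cases toward higher toxicity in this test. The earlier swap at this position had stayed within the scatter, so only the trimethoxyphenyl compound shows that this position is not indifferent to the group it carries. Compared with 3-chlorophenyl, the entering group has 12 heavy atoms rather than 7 and 3 hydrogen-bond acceptors rather than 0, but nothing available here connects either difference, or any other feature of the group, to the lower number.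

The compounds shown do not separate the contribution of each methoxy group, so it remains open whether a single methoxy group would produce part of this step or whether the full 3,4,5-trimethoxyphenyl pattern is required. They also leave open how this read-out would respond at the same amide-type nitrogen to a phenyl ring carrying a dimethylamino group or a carboxylic acid.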